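The compounds below may be only part of what the source reports. "The series", "measured", "known", "first", "only" and "open" are said of these compounds alone.

Notes on a small series sharing one core. Compound 1 `Cc1ccc(NC(=O)c2cccc(/C=C3\CC(=O)N(c4ccccc4)C3=O)c2)cc1C` carries 3,4-dimethylphenyl on the amide-type nitrogen. In an ADME assay on SW480 cells (Homo sapiens) for cytotoxicity, read by MTT assay, with a stated time of 72 h (a lower number here means a stronger inhibitor, a higher number a weaker inhibitor), compound 1 gives > 100000 nM, which is a limit of the measurement and not a number. Compound 2 `O=C(Nc1ccc(Cl)cc1)c1cccc(/C=C2\CC(=O)N(Cc3ccccc3)C2=O)c1` is the other measured member of the series. In this assay compound 2 gives > 100000 nM, again a limit rather than a number. For the measured compounds named here, compound 1 thus stands at the limit of > 100000 nM in this assay, at which 2 of the 2 values shown sit, and no step between measured compounds can be drawn from these two values, since neither is a finished number.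

Compound 3 `CCOc1ccc(NC(=O)c2cccc(/C=C3\CC(=O)N(c4ccccc4)C3=O)c2)cc1` is the next to be measured. It differs from compound 1 in one place: 4-ethoxyphenyl in place of 3,4-dimethylphenyl on an amide-type nitrogen.

Going by the values given here, both measured values rest at the same limit, so the series offers no step against which to weigh this change. The expected step is a step that the limit leaves unreadable from compound 1 to compound 3 in this assay, with no movement beyond the scatter anticipated. Compound 3 is accordingly expected to give 150000 nM in this assay, with a range from 40000 nM to 600000 nM, and most likely reported once more only as a limit.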

Compound 3, half-maximal inhibitory concentration: 91500 nM
Estimate against measurement, compound 3: 1.6-fold (0.21 log units) above; the measured number falls inside the stated range.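

For the compounds shown here, compound 3 gives the first finished number of the series in this assay, so 4-ethoxyphenyl in place of 3,4-dimethylphenyl on an amide-type nitrogen can be given a floor on its step, which no earlier pair allowed. That step reads as an at least 1.0-fold lower number from compound 1 to compound 3 (0.03 log units; that floor lies within the scatter), and since the floor lies within the scatter, the change cannot be said to have moved the value at this position. The one finished number also gives no sign of a real gain, as it stands close to the limit that still holds the other compounds: the limit of > 100000 nM in this assay, at which 2 of the 3 values shown sit.

As far as these compounds go, how far the true value of compound 1 lies from that of compound 3 stays unknown, so the size of this change cannot be settled from these compounds. Going by these compounds alone, also open is whether a phenyl ring carrying an amine or a carboxylic acid, or a longer chain such as butoxy in place of ethoxy, on that amide-type nitrogen would give a number clearly lower than the one compound 3 gives.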